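Working notes on pyridyl variants of the shared core

The compounds below may be only part of what the source reports. "The series", "measured", "known", "first", "only" and "open" are said of these compounds alone.

Measured so far:
compound 1, `COc1cc(OC)c(C(=O)/C=C/c2cn(-c3ccccc3)nc2-c2ccsc2)c(OC)c1`: 2700 nM
compound 2, `COc1cc(OC)c(C(=O)/C=C/c2cn(-c3ccccc3)nc2-c2cccnc2)c(OC)c1`: 1000 nM

Both compounds were run in a functional assay on MCF7 cells (Homo sapiens) for inhibition, read by sulforhodamine B assay, with a stated time of 72 h; on this read-out lower numbers stand for stronger inhibition and higher numbers for weaker inhibition. Going by the values given here, of the two numbers on hand, compound 2 gives the lower one; the single step recorded, a 2.7-fold lower number from compound 1 to compound 2 (0.43 log units; beyond the scatter), is beyond the scatter, so compound 2 stands as the stronger of the pair on this read-out.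

Compound 3, `COc1cc(OC)c(C(=O)/C=C/c2cn(-c3ccccc3)nc2-c2ccncc2)c(OC)c1`, differs from compound 2 in one place: pyridin-4-yl in place of pyridin-3-yl on an aromatic carbon. The two have the same atoms, joined differently, the change being the position of the ring nitrogen within the pyridine that hangs off the five-membered ring.

Among the compounds with values here, no measured step bears directly on this exchange. Within the data shown here, the one step available concerns thiophen-3-yl against pyridin-3-yl at the same position and gives no guide to which way a move of the nitrogen within the pyridine would go. With no basis for a direction, the expectation for the step from compound 2 to compound 3 is no change at the digits printed from compound 2 to compound 3 (within the scatter), which lies within the scatter. For compound 3 the estimated value in this assay is 1000 nM, with an expected range from 400 nM to 2500 nM.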

Compound 3, half-maximal inhibitory concentration: 1600 nM
Compound 3: the middle estimate sits 1.6-fold (0.20 log units) below what was measured, within the range that was stated.
By their numbers in this assay, from the lowest: compounds 2, 3 and 1 (each within the scatter of the next, the first and the last beyond it).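

Working notes, continued

In this assay, moving the nitrogen within the pyridine at this position gives a 1.6-fold higher number from compound 2 to compound 3 (0.20 log units; within the scatter) and so does not separate pyridin-3-yl from pyridin-4-yl on this read-out. Against thiophen-3-yl the two pyridines no longer read alike: pyridin-3-yl gives a 2.7-fold lower number from compound 1 to compound 2 (0.43 log units; beyond the scatter) while pyridin-4-yl gives a 1.7-fold lower number from compound 1 to compound 3 (0.23 log units; within the scatter), so only the first exchange clears the scatter and compound 3 does not support a general separation of pyridines from thiophen-3-yl at this position. No supporting data are at hand to explain these numbers.

The compounds shown leave open whether pyridin-2-yl, with the nitrogen in the one placement not yet covered here, would stay with the two pyridines or fall apart from them on this read-out. They also leave open how a non-aromatic group such as an amine or a carboxylic acid, or a substituted pyridine such as a methoxypyridine, would read at the same position on the shared core.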